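Alkyl variation at the ring nitrogen of the shared core

The source may report more compounds than this note shows. Statements on the series, on what has been measured and on what is new or still open speak of the compounds shown alone.

Measured compounds:
compound 1 `COc1cc(Cc2nc3c(N)nc(F)nc3n2CC2CCCO2)cc(OC)c1OC`, 22900 nM in a functional assay on MCF7 cells (Homo sapiens) for antiproliferative activity; on this read-out lower numbers stand for stronger inhibition and higher numbers for weaker inhibition
compound 2 `CCCn1c(Cc2cc(OC)c(OC)c(OC)c2)nc2c(N)ncnc21`, 46800 nM
compound 3 `CCCn1c(Cc2cc(OC)c(OC)c(OC)c2)nc2c(N)nc(F)nc21`, 25100 nM

Among the measured compounds shown here, compound 2 and compound 3 lie within the scatter of one another, as the step of a 1.9-fold lower number from compound 2 to compound 3 (0.27 log units; within the scatter) shows; the gap from compound 2 to compound 1 is beyond the scatter, though no single-point step connects them. Compound 4 `COc1cc(Cc2nc3c(N)ncnc3n2CC2CCC2)cc(OC)c1OC` has not yet been measured. It differs from compound 2 by cyclobutyl in place of ethyl on a saturated chain carbon bound to an aromatic nitrogen. For the measured compounds named here, the one measured step at the same place, a 1.1-fold higher number from compound 1 to compound 3 (0.04 log units; within the scatter), exchanges one group on a saturated chain carbon bound to an aromatic nitrogen for another and stays within the scatter. On that basis a change at this position is not expected to move the number beyond the scatter in either direction. The step from compound 2 to compound 4 is therefore estimated as a 1.1-fold lower number from compound 2 to compound 4 (0.05 log units; within the scatter). For compound 4 the expected value in this assay is 42000 nM, with a range from 18000 nM to 95000 nM.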

Compound 4, half-maximal inhibitory concentration: 45700 nM
Compound 4: the middle estimate sits 1.1-fold (0.04 log units) below what was measured; low and high end bracket the measured number.
By their numbers in this assay, from the lowest: compounds 1, 3, 4 and 2 (each within the scatter of the next, the first and the last beyond it).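

In this assay, cyclobutyl in place of ethyl on a saturated chain carbon bound to an aromatic nitrogen gives a 1.0-fold lower number from compound 2 to compound 4 (0.01 log units; within the scatter), so a group carrying a four-membered non-aromatic ring of carbon only leaves the number within the scatter. Among the compounds shown here, the earlier step at this place, a 1.1-fold higher number from compound 1 to compound 3 (0.04 log units; within the scatter), was read on the fluoro-bearing form of the shared core; the new step gives the first reading on the form without fluoro, and both steps stay within the scatter. Nothing available on the series offers an explanation for this result.

Still open, from the compounds shown here alone, is whether an amine, a carboxylic acid or a longer chain such as hexyl at this place would move the number beyond the scatter. Also open, going by these compounds, is whether cyclobutyl gives the same result on the fluoro-bearing form of the core.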